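The compounds below may be only part of what the source reports. "The series", "measured", "known", "first", "only" and "open" are said of these compounds alone.

Measured so far in a functional assay on DU-145 cells (Homo sapiens) for inhibition, read by MTT assay, with a stated time of 48 h; a higher number here means a weaker inhibitor, a lower number a stronger inhibitor:
- compound 1 `Cn1c(/C=C2\SC(=O)N(CC(=O)Nc3cc(C(C)(C)C)on3)C2=O)nc2ccccc21`: 31400 nM
- compound 2 `Cn1c(/C=C2\SC(=O)N(CC(=O)N3CCOCC3)C2=O)nc2ccccc21`: 41100 nM
- compound 3 `CCn1c(/C=C2\SC(=O)N(CC(=O)Nc3cc(C(C)(C)C)on3)C2=O)nc2ccccc21`: > 50000 nM (a limit of this assay, not a number)

Compound 1 gives the lowest of the two numbers shown in this assay; compound 2 sits nearest, a 1.3-fold higher number from compound 1 to compound 2 (0.12 log units; within the scatter). For compound 3 only the limit of > 50000 nM in this assay, at which 1 of the 3 values shown sits, is recorded; an at least 1.5-fold higher number from compound 1 to compound 3 (0.20 log units; that floor lies within the scatter).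

Compound 4 `Cn1c(/C=C2\SC(=O)N(CC(=O)Nc3nc(-c4ccccc4)cs3)C2=O)nc2ccccc21` differs from compound 1 in one place: 4-phenyl-1,3-thiazol-2-yl in place of 5-(tert-butyl)-1,2-oxazol-3-yl on an amide-type nitrogen. Going by the values given here, no measured step replaces this group with another aryl amide. Among the compounds with values here, the closest step is the one from compound 1 to compound 2, which also exchanges the group on the amide-type nitrogen and stayed within the scatter; the step to compound 3 concerns the saturated chain carbon bound to the aromatic nitrogen and does not bear on the amide end. The expectation is therefore no step beyond the scatter in this assay, in either direction: a 1.0-fold lower number from compound 1 to compound 4 (0.02 log units; within the scatter). Compound 4 is estimated at 30000 nM, within 12000 nM to 60000 nM.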

Compound 4, half-maximal inhibitory concentration: 31400 nM
The estimate for compound 4 lay 1.0-fold (0.02 log units) below the measured number, within the range that was stated.
By their numbers in this assay, from the lowest: compounds 1, 4 and 2 (each within the scatter of the next). At a limit, above all of these: compound 3.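

Placing 4-phenyl-1,3-thiazol-2-yl on the amide-type nitrogen gives no change at the digits printed from compound 1 to compound 4 (within the scatter) in this assay, so this end of the series now has a second aryl amide to compare directly with compound 1. The entering group adds one six-membered aromatic ring of carbon only, yet this exchange, like the earlier one giving a 1.3-fold higher number from compound 1 to compound 2 (0.12 log units; within the scatter), produces no step beyond the scatter. No measurement shown bears on why the number stays put.

Going by these compounds, it remains open whether any group on the amide-type nitrogen can move the number beyond the scatter in this assay. A carboxylic acid or a primary amine on the phenyl ring of the 4-phenyl-1,3-thiazol-2-yl group would test this end of the series more sharply.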